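This account rests on a few compounds, and the source may have more. Where it says the series, first, only, none or still open, it means among the compounds named here.

Measured compounds in a functional assay on HepG2 cells (Homo sapiens) for antiproliferative activity, read by MTT assay, with a stated time of 48 h; on this read-out higher numbers stand for weaker inhibition and lower numbers for stronger inhibition:

Compound 1, `Cc1ccccc1-n1nncc1CN1C(=O)C2(C(C#N)=C(N)Oc3c2c2nc4ccccc4nc2c2ccccc32)c2ccccc21`, gives the assay limit > 50000 nM.
Compound 2, `Cc1cccc(-n2nncc2CN2C(=O)C3(C(C#N)=C(N)Oc4c3c3nc5ccccc5nc3c3ccccc43)c3ccccc32)c1`, gives the assay limit > 50000 nM.
Compound 3, `Cc1ccccc1-n1nncc1CN1C(=O)C2(C(C#N)=C(N)Oc3c(N)cc4nc5ccccc5nc4c32)c2ccccc21`, gives the assay limit > 50000 nM.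

All three values are limits, not numbers, so in this assay the series has not yet produced a readable inhibitory concentration. The change from compound 1 to compound 2 is 3-methylphenyl in place of 2-methylphenyl on an aromatic nitrogen; the step it made, a step that the two limits leave unreadable from compound 1 to compound 2, cannot be sized because both ends are limits, as the limit of > 50000 nM in this assay, at which 3 of the 3 values shown sit, records. The difference between the core of compound 1 and the core of compound 3 is not broken down here.

Compound 4, `Cc1cccc(-n2nncc2CN2C(=O)C3(C(C#N)=C(N)Oc4c(N)cc5nc6ccccc6nc5c43)c3ccccc32)c1`, not yet measured in this assay, differs from compound 3 by 3-methylphenyl in place of 2-methylphenyl on an aromatic nitrogen, the same change as from compound 1 to compound 2, at the same place.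

For compound 4 the expected step is a step that the limit leaves unreadable from compound 3 to compound 4, resting on the limit of compound 3, > 50000 nM, and on (the limit of > 50000 nM in this assay, at which 3 of the 3 values shown sit), which shows every value of the series sitting at the limit. Compound 4 is therefore estimated at 70000 nM, with a range of 25000 nM to 200000 nM, and most likely reported only as a limit.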

Compound 4, half-maximal inhibitory concentration: > 50000 nM
Compound 4 ended at the assay's limit (the forecaster's own chance of this, stated with the estimate: 80%); the middle value does not contradict the limit.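

In this assay, compound 3 and compound 4 both stand as limits rather than numbers, so no size can be read for the step between them: the limit of > 50000 nM in this assay, at which 4 of the 4 values shown sit.

The compounds shown leave open whether any member of the series has a readable inhibitory concentration in this assay, and whether 3-methylphenyl in place of 2-methylphenyl changes activity on either core.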